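The compounds below may be only part of what the source reports. "The series", "measured", "known", "first", "only" and "open" are said of these compounds alone.

Measured so far in an assay on cells for inhibition of ubiquitin carboxyl-terminal hydrolase isozyme L5 (Homo sapiens), read by fluorescence, with a stated time of 30 min; a higher number here means a weaker inhibitor, a lower number a stronger inhibitor:

compound 1 `O=C(O)c1cc(Cn2cc(-c3ccc(NCc4ccccc4)cc3)nn2)cc(-c2ccccc2C(=O)O)c1` gives 215000 nM
compound 2 `Nc1ccc(-c2cn(Cc3cc(C(=O)O)cc(-c4ccccc4C(=O)O)c3)nn2)cc1` gives 80500 nM
compound 3 `CC(C(=O)O)c1ccc(C(=O)c2cccc(-c3occc3C(=O)O)c2)s1` gives 75700 nM

Compound 1 stands highest of the three numbers in this assay ; its nearest neighbour is compound 2 with a step of a 2.7-fold lower number from compound 1 to compound 2 (0.43 log units; beyond the scatter) and the furthest is compound 3, whose value sits somewhat lower still. Compound 3 shares no single-point relation with compound 1, so its number is noted only as a reference point for the series.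

Compound 4 `CC(=O)Nc1ccc(-c2cn(Cc3cc(C(=O)O)cc(-c4ccccc4C(=O)O)c3)nn2)cc1` is not yet measured. It differs from compound 1 by acetyl in place of benzyl on a nitrogen on an aromatic ring.

Among the compounds with values here, the one measured step that bears on this change is a 2.7-fold lower number from compound 1 to compound 2 (0.43 log units; beyond the scatter), in which the benzyl was taken off the same nitrogen and a hydrogen left in its place, giving a modest fall in the number beyond the scatter. Compound 4 also loses the benzyl, but takes on an acetyl at that nitrogen instead of a hydrogen, so it is not the same change ; it sits, in terms of what is removed and what enters, between compound 1 and compound 2. On that basis the expected step for compound 4 is a modest fall, a 1.8-fold lower number from compound 1 to compound 4 (0.25 log units; within the scatter), smaller than or close to the step from compound 1 to compound 2. The expected value for compound 4 in this assay is therefore 120000 nM, with a range from 50000 nM to 300000 nM.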

Compound 4, half-maximal inhibitory concentration: 80900 nM
Beside the measured number, compound 4's estimate is 1.5-fold (0.17 log units) above it; the range from low to high includes it.
By their numbers in this assay, from the lowest: compounds 3, 2 and 4 (each within the scatter of the next); then compound 1.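

Replacing benzyl with acetyl on a nitrogen on an aromatic ring gives a 2.7-fold lower number from compound 1 to compound 4 (0.42 log units; beyond the scatter) in this assay, so the lower number at this position does not depend on the free amine of compound 2. Acetyl in place of hydrogen gives a 1.0-fold higher number from compound 2 to compound 4 (0.00 log units; within the scatter), so the assay does not tell these two groups apart at this nitrogen, even though the acetyl adds a carbonyl. Of the three groups shown at this place, only benzyl, the one that carries an aromatic ring, stands apart from the others, and no measurement at hand offers an explanation for this.

The compounds shown leave open whether the higher number of compound 1 follows the aromatic ring of the benzyl or simply the size of the group; a cyclohexylmethyl group or a longer alkyl chain on the same nitrogen would separate the two. Going by these compounds, the core is also the same in compound 1, compound 2 and compound 4, so the effect of an ester in place of either carboxylic acid remains open.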